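Swapping fluoro for methyl on a cinnamate isourea ester

The source may report more compounds than this note shows. Statements on the series, on what has been measured and on what is new or still open speak of the compounds shown alone.

Measured so far:
Compound 1, `COC(=O)[C@H](CO)NC(=O)/C=C/c1ccc(OC)cc1`: 100%
Compound 2, `O=C(/C=C/c1ccc(F)cc1)O/C(=N/C1CCCCC1)NC1CCCCC1`: 82.5%

The account concerns cytotoxicity in an ADME assay on Vero cells (Chlorocebus sabaeus) for cytotoxicity, read by WST assay, tested at 50 ug/mL (a lower number here means a stronger effect, a higher number a weaker effect of the compound at the concentration tested), in which compound 1 gives 100% and compound 2 gives 82.5%. Of these two numbers, compound 2 holds the lower one; compound 1 stands higher, and the gap between them lies beyond the usual scatter of such measurements. Among the measured compounds shown here, compound 2 therefore marks the stronger effect of the pair at the concentration tested, though with only two compounds nothing general can be drawn from this.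

The step now followed leads from compound 2 to compound 3, `Cc1ccc(/C=C/C(=O)O/C(=N/C2CCCCC2)NC2CCCCC2)cc1`, which has not yet been measured in this assay. The structural change is methyl in place of fluoro on an aromatic carbon. It is a small exchange of one heavy atom for another on the aromatic ring, away from the ester and the isourea part, which stay the same.

For the measured compounds named here, no step between measured compounds exists to lean on here. Given how small the change is, compound 3 is expected to differ from compound 2 by a number 2.5 percentage points higher from compound 2 to compound 3 (within the scatter), which is no step beyond the scatter. Compound 3 is thus estimated at 85% in this assay, within a range from 65% to 100%.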

Compound 3, a percentage reported as activity, at one concentration (the size of the read-out at that concentration, not a potency): 79.3%
The estimate for compound 3 lay 5.7 percentage points above the measured number; the range from low to high includes it.
By their numbers in this assay, from the lowest: compounds 3 and 2 (each within the scatter of the next); then compound 1.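

In this assay, among the compounds shown here, putting methyl in place of fluoro on this aromatic carbon, para to a large group, gives a number 3.2 percentage points lower from compound 2 to compound 3 (within the scatter), and this is the first step between measured compounds that differ in one place. At this position, then, the read-out at the single concentration tested does not separate the 4-fluorophenyl compound from the 4-methylphenyl compound, so this exchange of one heavy atom for another leaves compound 2 and compound 3 within the scatter of each other, with no sign that either group matters more than the other here. Nothing measured on these compounds offers an explanation for this result, and the step is recorded here only as an observation.

On these data alone, whether a group of another kind at the same place, such as an amine or a carboxylic acid, would carry the read-out beyond the scatter remains open, as one step covers only fluoro and methyl. Also open, as far as these compounds go, is how the read-out would respond if the two cyclohexyl groups of the isourea part gave way to a longer chain, with the 4-methylphenyl group kept unchanged.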